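A Fluorophenyl for a Dimethoxyphenyl on One Shared Core

The source may hold more compounds than are shown below. What is called first, only, known or untested is meant among the compounds shown, and "the series" means these compounds.

Of the compounds shown here, three sharing one core have been measured in a functional assay on U-251 cells (Homo sapiens) for inhibition, read by sulforhodamine B assay, with a stated time of 48 h; on this read-out higher numbers stand for lower toxicity in this test and lower numbers for higher toxicity in this test. Compound 1 `Nc1cc(N)c2nc(-c3ccccc3)c(Oc3ccc(Cl)c(Cl)c3)nc2c1` gives 83200 nM in this assay. Compound 2 `Nc1cc(N)c2nc(-c3ccccc3)c(NCc3ccc(Cl)c(Cl)c3)nc2c1` is reported in this assay only as a limit, < 100000 nM, not as a number. Compound 3 `COc1ccc(CNc2nc3cc(N)cc(N)c3nc2-c2ccccc2)cc1OC` gives 89100 nM in this assay, the higher of the two numbers available, with compound 1 nearest at a gap that lies within the usual scatter, so no order between them can be claimed. For the measured compounds named here, the only measured step touching the same position, a step that the limit leaves unreadable from compound 2 to compound 3, cannot be sized owing to the limit of < 100000 nM in this assay, at which 1 of the 3 values shown sits.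

Compound 4 `Nc1cc(N)c2nc(-c3ccccc3)c(NCc3ccc(F)cc3)nc2c1` has not yet been measured in this assay. It differs from compound 3 by 4-fluorophenyl in place of 3,4-dimethoxyphenyl on a saturated chain carbon bound to a nitrogen on an aromatic ring. Going by the values given here, no measured step with a readable size bears on a change at this position, and the two readable numbers, from compound 1 and compound 3, sit within the scatter of each other despite differing elsewhere. The writer therefore expects a step from compound 3 to compound 4 of a 1.0-fold lower number from compound 3 to compound 4 (0.02 log units; within the scatter), that is, nothing beyond the scatter in either direction. On that basis compound 4 is estimated at 85000 nM, with a range from 40000 nM to 180000 nM.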

Compound 4, concentration lethal to 50% of the cells: 6310 nM
Compound 4: the middle estimate sits 13-fold (1.13 log units) above what was measured; measured number below the stated range.
By their numbers in this assay, from the lowest: compound 4; then compounds 1 and 3 (each within the scatter of the next).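

The position on a saturated chain carbon bound to a nitrogen on an aromatic ring turns out to be sensitive in this assay: putting 4-fluorophenyl in place of 3,4-dimethoxyphenyl gives a 14-fold lower number from compound 3 to compound 4 (1.15 log units; beyond the scatter). The broader change of (4-fluorobenzyl)amino in place of 3,4-dichlorophenoxy on an aromatic carbon is also large, at a 13-fold lower number from compound 1 to compound 4 (1.12 log units; beyond the scatter). The earlier compounds shown here offered no readable step at this position, whereas compound 4 now shows that a change of the aromatic group here alone can move the read-out beyond the scatter, towards higher toxicity in this test.

Compound 2 is reported only as a limit, so its steps to compound 3 and to compound 4 cannot be read, and 3,4-dichlorophenyl cannot be placed against the other two groups, because of this: the limit of < 100000 nM in this assay, at which 1 of the 4 values shown sits.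

As far as these compounds go, it also remains open whether the entry of the fluorine or the loss of the methoxy groups carries the step, a question that an unsubstituted phenyl, a 4-methoxyphenyl or a 4-chlorophenyl on the same chain carbon would address.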